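Replacing the acid of compound 3 with a furanone ring

The source may hold more compounds than are shown below. What is called first, only, known or untested is meant among the compounds shown, and "the series" means these compounds.

Measured compounds and their values in a functional assay on K562 cells (Homo sapiens) for cytotoxicity, read by MTT assay; on this read-out higher numbers stand for lower toxicity in this test and lower numbers for higher toxicity in this test:
compound 1, `C/C(=C/CC[C@@H](C)CC(=O)O)CC/C=C(/C)CCCc1ccoc1`: > 100 ug/mL, a limit of the test.
compound 2, `COC(=O)C(C)(O)[C@@](O)(C[C@H](C)CC/C=C(/C)CC/C=C(/C)CCCc1ccoc1)C(=O)OC`: 46 ug/mL.
compound 3, `C/C(=C\CCc1ccoc1)CC/C=C(\C)CCC[C@@H](C)CC(=O)O`: > 100 ug/mL, a limit of the test.

Compound 3 thus sits at the limit rather than at a number, and it shares that position with compound 1 (the limit of > 100 ug/mL in this assay, at which 2 of the 3 values shown sit). Going by the values given here, only compound 2 gives a real number in this assay, and with it compound 2 is the one measured compound that shows toxicity here. Among the compounds with values here, no two measured compounds differ in just one place, so no measured step is known.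

Compound 4, `CC1=C(O)/C(=C/[C@H](C)CCC/C(C)=C/CC/C(C)=C/CCc2ccoc2)OC1=O`, is the next compound. Compared with compound 3 the change is a group of 9 heavy atoms (6 carbon, 3 oxygen; one five-membered non-aromatic ring with 1 hetero atom) in place of a group of 4 heavy atoms (2 carbon, 2 oxygen; no ring), on a saturated chain carbon bound to two saturated chain carbons. Because compound 3 gives only a limit, any move is expected to show as a number appearing where none was seen. The expected step from compound 3 to compound 4 in this assay is an at least 4.0-fold lower number from compound 3 to compound 4 (0.60 log units; beyond the scatter), toward higher toxicity. For compound 4 the estimated value in this assay is 25 ug/mL, with a likely range from 6 ug/mL to 90 ug/mL.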

Compound 4, concentration lethal to 50% of the cells: 39 ug/mL
The estimate for compound 4 lay 1.6-fold (0.19 log units) below the measured number; measured number inside the range.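

Going by these compounds alone, at this saturated chain carbon, replacing the carboxymethyl group with a group carrying one five-membered non-aromatic ring gives the first measured step in this set: in this assay there is an at least 2.5-fold lower number from compound 3 to compound 4 (0.40 log units; beyond the scatter), toward higher toxicity. This place on the chain is therefore not indifferent to what it carries, and this single change is enough to turn a limit into a real number. The true size of the step remains unknown, since compound 3 sits at a limit of the test: the limit of > 100 ug/mL in this assay, at which 2 of the 4 values shown sit.

The compounds shown do not reveal which part of the entering group accounts for the step, the ring itself or its double bonds. Going by these compounds, whether a simple amide or a methyl ester at this carbon would also move the number remains open.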